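Moving a carbon on the amide side chain

The source may report more compounds than this note shows. Statements on the series, on what has been measured and on what is new or still open speak of the compounds shown alone.

In a physicochemical assay for lipophilicity, read by HPLC (on this read-out higher numbers stand for higher lipophilicity and lower numbers for lower lipophilicity), compound 3 (`Cc1ccc(CNC(=O)C(CCO)N(C)CCC=C(c2sccc2C)c2sccc2C)cc1`) gives 6.2. That lies within the scatter of compound 2 (`Cc1ccsc1C(=CCCN(C)C(CCO)C(=O)NCc1ccc(F)cc1F)c1sccc1C`) at 6.37 and well clear of compound 1 (`Cc1ccsc1C(=CCCN(C)C(CCO)C(=O)N1CCOCC1)c1sccc1C`) at 4.75. Compound 4 (`Cc1ccsc1C(=CCCN(C)C(CCO)C(=O)NC(C)c1ccccc1)c1sccc1C`) keeps the shared core but carries 1-phenylethyl in place of 4-methylbenzyl on an amide-type nitrogen. With (2,4-difluorobenzyl)amino in place of morpholin-4-yl, the data show a number 1.62 log units higher from compound 1 to compound 2 (beyond the scatter). With (4-methylbenzyl)amino in that place, they show a number 1.45 log units higher from compound 1 to compound 3 (beyond the scatter). Both steps are large, but both start from morpholin-4-yl, so they say little about this change. The step closest in kind, with 4-methylphenyl in place of 2,4-difluorophenyl, is a number 0.17 log units lower from compound 2 to compound 3 (within the scatter). Going by the values given here, no measured pair tests the change to 1-phenylethyl directly. No step beyond the scatter is therefore expected in this assay. The expected change is a number 0.10 log units lower from compound 3 to compound 4 (within the scatter). For compound 4 the estimated value is 6.1, with an expected range from 5.7 to 6.5.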

Compound 4, partition coefficient: 6.1
The estimate for compound 4 equals the measured number at the digits printed; the range from low to high includes it.
By their numbers in this assay, from the lowest: compound 1; then compounds 4, 3 and 2 (each within the scatter of the next).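

Putting 1-phenylethyl in place of 4-methylbenzyl on an amide-type nitrogen, two groups of the same atoms joined differently, gives a number 0.10 log units lower from compound 3 to compound 4 (within the scatter) in this assay and so leaves no readable change at this position. With 1-phenylethyl in place of 2,4-difluorobenzyl the result is a number 0.27 log units lower from compound 2 to compound 4 (within the scatter) and the three compounds carrying an aromatic ring on this nitrogen stay together, whereas (1-phenylethyl)amino in place of morpholin-4-yl on a carbonyl carbon gives a number 1.35 log units higher from compound 1 to compound 4 (beyond the scatter) and this large step stands apart from them. The compounds shown leave open whether 2-phenylethyl, a longer chain, on the same nitrogen would also stay with these three, and whether a carboxylic acid or an amine on the aromatic ring would shift the number. Nothing measured here explains these numbers.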